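Indole oxalamides: isobutyl to acid-bearing chain on indole nitrogen

The source may hold more compounds than are shown below. What is called first, only, known or untested is meant among the compounds shown, and "the series" means these compounds.

Measured so far, in a functional assay on FaDu cells (Homo sapiens) for cytotoxicity, read by MTT assay, with a stated time of 72 h; a lower number here means that less compound is tolerated, a higher number that more compound is tolerated:
- compound 1, `COc1ccc(NC(=O)C(=O)c2cn(CC(C)C)c3ccccc23)cn1`: 317 nM
- compound 2, `COCCn1cc(C(=O)C(=O)Nc2ccc(OC)nc2)c2cc(Cl)ccc21`: > 10000 nM, a limit of the assay, not a number
- compound 3, `COCCn1cc(C(=O)C(=O)Nc2ccnc(OC)c2)c2ccccc21`: 235 nM

Compound 1 gives the higher of the two numbers in this assay, but its nearest neighbour is compound 3, and the two lie within the scatter; no order between them is claimed. For compound 2 only the limit of > 10000 nM in this assay, at which 1 of the 3 values shown sits, is known, and it stands apart from the two numbers. Nothing in this set says what the limit of compound 2 rests on.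

Compound 4, `COc1ccc(NC(=O)C(=O)c2cn(C(C)(C)COCC(=O)O)c3ccccc23)cn1`, is not yet measured. It differs from compound 1 in one place: a group of 9 heavy atoms (6 carbon, 3 oxygen; no ring) in place of a group of 4 heavy atoms (4 carbon; no ring), on an aromatic nitrogen. For the measured compounds named here, no pair among the measured compounds differs in one place, so no measured step guides the size of this change. The expectation for this assay is a step upward, somewhat beyond the scatter, with wide uncertainty in either direction. Compound 4 is expected to give 1500 nM, with a range from 400 nM to 8000 nM. That estimate means a step of a 4.7-fold higher number from compound 1 to compound 4 (0.68 log units; beyond the scatter).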

Compound 4, concentration lethal to 50% of the cells: > 10000 nM
Compound 4: a limit, no number; the forecaster's own chance of this, stated with the estimate: 20%; middle value at least 6.6-fold (0.82 log units) away from the limit.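

For the compounds shown here, exchanging isobutyl for the acid-bearing chain on the aromatic nitrogen is the first one-place change that can be read in this assay, and it gives an at least 31-fold higher number from compound 1 to compound 4 (1.49 log units; beyond the scatter). The value of compound 4 is a limit of the assay and not a number, so this step fixes only a lower bound on the size of the change. That limit is now shared by a second compound: the limit of > 10000 nM in this assay, at which 2 of the 4 values shown sit.

The compounds shown do not separate the carboxylic acid from the rest of the chain, and a methyl ester on the same chain would be the closest test of that. Going by these compounds alone, compound 4 is the only compound here that carries this chain, so its effect on any other core remains open.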